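Chloro Added to the Benzyl Group of Compound 3

The source may report more compounds than this note shows. Statements on the series, on what has been measured and on what is new or still open speak of the compounds shown alone.

Three compounds of the series have a number in a toxicity assay on HaCaT cells (Homo sapiens) for cytotoxicity, tested at 250 uM (a lower number here means a stronger effect, a higher number a weaker effect of the compound at the concentration tested), so far. Compound 1 `O=S(=O)(Nc1nnc(SCc2ccccc2)s1)c1ccccc1` is the parent; in this assay compound 1 gives 68%. Compound 2 `O=S(=O)(Nc1nnc(SCc2ccc(Cl)cc2)s1)c1ccccc1` differs from compound 1 by chloro in place of hydrogen on an aromatic carbon and in this assay compound 2 gives 71%, a step of a number 3 percentage points higher from compound 1 to compound 2 (within the scatter). Compound 3 `Cc1ccc(S(=O)(=O)Nc2nnc(SCc3ccccc3)s2)cc1` differs from compound 1 by methyl in place of hydrogen on an aromatic carbon, and in this assay compound 3 gives 65%, a step of a number 3 percentage points lower from compound 1 to compound 3 (within the scatter). The values of compound 2 and compound 3 are within the scatter of each other; none of the three stands apart.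

Compound 4 `Cc1ccc(S(=O)(=O)Nc2nnc(SCc3ccc(Cl)cc3)s2)cc1` has not yet been measured in this assay. It differs from compound 3 by chloro in place of hydrogen on an aromatic carbon. Among the measured compounds shown here, this is the same change as the one from compound 1 to compound 2, at a place described in the same words, and the difference between the two cores is methyl in place of hydrogen on an aromatic carbon. The change occurs twice among the compounds shown, once measured. The step from compound 3 to compound 4 is expected to be about a number 3 percentage points higher from compound 3 to compound 4 (within the scatter), because the earlier step of a number 3 percentage points higher from compound 1 to compound 2 (within the scatter) stayed within the scatter. Compound 4 is estimated at 68%, from 56% to 80%, resting on compound 3 with its 65%. This rests on a single measured pair, so the range is kept wide.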

Compound 4, a percentage reported as activity, at one concentration (the size of the read-out at that concentration, not a potency): 70%
Beside the measured number, compound 4's estimate is 2 percentage points below it; the measured number falls inside the stated range.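

In this assay the chloro change gives a number 5 percentage points higher from compound 3 to compound 4 (within the scatter), and set beside its earlier reading on the core of compound 1, it agrees: the same change on two cores in this assay, a number 3 percentage points higher (within the scatter) from compound 1 to compound 2 and a number 5 percentage points higher (within the scatter) from compound 3 to compound 4, 2 percentage points apart, within the scatter of two such steps. The methyl change, read on the chloro-bearing pair, gives a number 1 percentage points lower from compound 2 to compound 4 (within the scatter), and it agrees in the same way with its earlier reading: the same change on two cores in this assay, a number 3 percentage points lower (within the scatter) from compound 1 to compound 3 and a number 1 percentage points lower (within the scatter) from compound 2 to compound 4, 2 percentage points apart, within the scatter of two such steps. Among the compounds shown here, all four steps lie within the scatter, which shows only that neither change moved the number measurably on either core; it does not show that a step of real size would carry from one core to another, and with just four compounds it supports no rule beyond them.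

The compounds shown vary only by chloro or hydrogen on the benzyl group and by methyl or hydrogen on the other aromatic ring, leaving open whether a different group, such as an amine, a carboxylic acid or a longer chain, would shift the number beyond the scatter. The read-out gives only the size of the effect at one concentration, and says nothing of how the four compounds would compare at other concentrations.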